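A hydroxy group in place of chloro

The compounds below may be only part of what the source reports. "The series", "measured", "known", "first", "only" and "open" are said of these compounds alone.

Of the compounds shown here, three sharing one core have been measured in a functional assay on MCF7 cells (Homo sapiens) for cytotoxicity; a higher number here means a weaker inhibitor, a lower number a stronger inhibitor. Compound 1 `C=C/C=C\[C@H](C)[C@H](OC(N)=O)[C@@H](C)[C@H](O)[C@@H](C)C/C(C)=C\[C@H](C)[C@@H](O)[C@@H](C)/C=C\CCc1ccc(Oc2ccccc2)cc1` gives 4000 nM, compound 2 `C=C/C=C\[C@H](C)[C@H](OC(N)=O)[C@@H](C)[C@H](O)[C@@H](C)C/C(C)=C\[C@H](C)[C@@H](O)[C@@H](C)/C=C\CCc1cccc(Cl)c1` gives 400 nM and compound 3 `C=C/C=C\[C@H](C)[C@H](OC(N)=O)[C@@H](C)[C@H](O)[C@@H](C)C/C(C)=C\[C@H](C)[C@@H](O)[C@@H](C)/C=C\CCc1cccc(OC)c1` gives 330 nM. Compound 2 thus has a lower number than compound 1 and lies within the scatter of compound 3. Compound 4 `C=C/C=C\[C@H](C)[C@H](OC(N)=O)[C@@H](C)[C@H](O)[C@@H](C)C/C(C)=C\[C@H](C)[C@@H](O)[C@@H](C)/C=C\CCc1cccc(O)c1` differs from compound 2 by one change: hydroxy in place of chloro on an aromatic carbon. For the measured compounds named here, only one measured step bears on it, methoxy in place of chloro on an aromatic carbon, a 1.2-fold lower number from compound 2 to compound 3 (0.08 log units; within the scatter). Going by the values given here, no measured compound carries hydroxy, so this guide is thin. The expected step is small, a 1.1-fold higher number from compound 2 to compound 4 (0.05 log units; within the scatter), and none beyond the scatter is anticipated. Compound 4 is estimated at 450 nM, with an expected range of 150 nM to 1300 nM.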

Compound 4, half-maximal inhibitory concentration: 130 nM
Estimate against measurement, compound 4: 3.5-fold (0.54 log units) above; measured number below the stated range.
By their numbers in this assay, from the lowest: compound 4; then compounds 3 and 2 (each within the scatter of the next); then compound 1.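

Both a 3.1-fold lower number from compound 2 to compound 4 (0.49 log units; beyond the scatter) and a 2.5-fold lower number from compound 3 to compound 4 (0.40 log units; beyond the scatter) are seen in this assay, so this aromatic carbon does respond to its substituent, which the chloro and methoxy pair, lying within the scatter of each other, had not shown. Methyl on the oxygen of compound 3 is enough to lose most of what the free hydroxy of compound 4 offers. No evidence is at hand on what lies behind these steps. The compounds shown leave open whether an amine or a carboxylic acid on this carbon would match compound 4 or stay with compounds 2 and 3.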